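From Methyl to Trifluoromethyl in Compound 3

The source may hold more compounds than are shown below. What is called first, only, known or untested is meant among the compounds shown, and "the series" means these compounds.

Of the compounds shown here, two have so far been tested in a functional assay on A549 cells (Homo sapiens) for antiproliferative activity, read by MTT assay, with a stated time of 72 h; a lower number here means a stronger inhibitor, a higher number a weaker inhibitor. Compound 1 (`COc1cc(-c2nc(N(C)C)sc2-c2ccc(C(F)(F)F)cc2)cc(OC)c1OC`) gives a limit of the assay rather than a number (> 10000 nM). Going by the values given here, compound 2 (`COc1cc(-c2nc(C)sc2-c2ccc(C)cc2)cc(OC)c1OC`) gives the only actual number (1950 nM), which makes it the single fixed reference point in this assay so far.

Compound 3 (`COc1cc(-c2nc(C)sc2-c2ccc(C(F)(F)F)cc2)cc(OC)c1OC`) is compound 2 with one change: trifluoromethyl in place of methyl on an aromatic carbon, para to a large group (trifluoromethyl in place of methyl on an aromatic carbon). Among the compounds with values here, no measured pair here isolates this change, so any forecast remains loose and must start from compound 2 (1950 nM) alone. A moderate weakening in this assay is expected, somewhat beyond the usual scatter, though a smaller shift would not be surprising. The estimated size of this move (a 2.1-fold higher number from compound 2 to compound 3 (0.31 log units; beyond the scatter)) carries wide uncertainty, and a result reported only as a limit remains possible. In this assay compound 3 is expected at about 4000 nM (estimated range 1300 nM to 10000 nM) once it is measured.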

Compound 3, half-maximal inhibitory concentration: 4290 nM
Compound 3: the middle estimate sits 1.1-fold (0.03 log units) below what was measured; measured number inside the range.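

With the rest of the molecule held fixed, trifluoromethyl in place of methyl on the aromatic carbon para to a large group gives a 2.2-fold higher number from compound 2 to compound 3 (0.34 log units; beyond the scatter), the first measured effect of this change in this assay; the swap costs only a modest amount, and compound 3 still gives a real number. With trifluoromethyl held fixed, methyl in place of dimethylamino on an aromatic carbon gives an at least 2.3-fold lower number from compound 1 to compound 3 (0.36 log units; beyond the scatter), which shows that trifluoromethyl alone does not carry compound 1 out of the measurable range and that this second place on the core also counts. That step has a lower bound only, since compound 1 gives a limit of the assay rather than a number: the limit of > 10000 nM in this assay, at which 1 of the 3 values shown sits.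

What the compounds shown leave open is whether this one pair says anything general about the position, for instance whether a chlorine, a methoxy group or a nitrile there would behave like methyl or like trifluoromethyl. They also leave open how far a smaller amine, or a longer chain, would be accepted in the place held by methyl in compound 3.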